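A few compounds are considered here, and "the series" means these few. Any claim that something is new, unique, unknown or untested is made for them only; others in the source may bear on it.

Three stilbene-type compounds carry two hydroxy groups or one hydroxy and one amino group on the shared core. Compound 1 `Oc1cccc(/C=C/c2ccccc2O)c1` and compound 2 `Oc1ccc(/C=C/c2ccccc2O)cc1` both pair a hydroxy on one ring with a hydroxy on the other; compound 3 `Nc1ccccc1/C=C/c1ccccc1O` pairs a hydroxy on one ring with an amino group on the other. In a functional assay on MCF7 cells (Homo sapiens) for inhibition, read by MTT assay, with a stated time of 2 days (a higher number here means a weaker inhibitor, a lower number a stronger inhibitor), compound 1 gives 20.1 ug/mL, compound 2 gives 21 ug/mL and compound 3 gives 39 ug/mL. The gaps from compound 3 to both others lie within the usual scatter, so none of the three stands apart from the rest.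

Compound 4 `COc1ccccc1/C=C/c1ccccc1N` has not yet been measured. It differs from compound 3 by methyl in place of hydrogen on an oxygen on an aromatic ring. Among the measured compounds shown here, no pair among the measured compounds shows what such a change does in this assay, so no measured step can guide the expectation. With a hydroxy becoming a methoxy on the core of compound 3, a small shift toward a weaker inhibitor is expected, of about a 1.3-fold higher number from compound 3 to compound 4 (0.11 log units; within the scatter), though a step hidden within the scatter is just as plausible. Compound 4 is therefore estimated at 50 ug/mL, with a range from 20 ug/mL to 120 ug/mL.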

Compound 4, half-maximal inhibitory concentration: > 100 ug/mL
Compound 4: only a limit was reported; the forecaster's own chance of this, stated with the estimate: 10%; middle value at least 2.0-fold (0.30 log units) away from the limit.
By their numbers in this assay, from the lowest: compounds 1, 2 and 3 (each within the scatter of the next). At a limit, above all of these: compound 4.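

In this assay, among the compounds shown here, the change from hydroxy to methoxy gives an at least 2.5-fold higher number from compound 3 to compound 4 (0.40 log units; beyond the scatter) and is the first difference in this set that clearly lies beyond the scatter. For the compounds shown here, for this pair, then, the hydrogen on that oxygen cannot be swapped for a methyl without a clear loss of inhibition, something the earlier compounds, with no single-change pair among them, could not show. The step rests on a limit and not on a number, so its true size stays open: the limit of > 100 ug/mL in this assay, at which 1 of the 4 values shown sits.

This one pair cannot tell whether a methoxy in place of a hydroxy on compound 1 or compound 2 would act the same way. Also open, from the compounds shown here alone, is how an ethyl chain or an acetyl group on that oxygen, or a fluorine in place of the hydroxy, would read in this assay on the same core.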